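Working notes: aryl exchange on the shared core

A few compounds are considered here, and "the series" means these few. Any claim that something is new, unique, unknown or untested is made for them only; others in the source may bear on it.

Measured compounds:
compound 1 `C=C(Br)C(=O)Nc1cccc(-c2cn3nc(-c4ccc(OCC)cc4)sc3n2)c1` — 1100 nM
compound 2 `Nc1cccc(-c2cn3c(-c4ccc(Cl)cc4)csc3n2)c1` — 11000 nM
compound 3 `Nc1cccc(-c2cn3nc(Cc4ccccc4)sc3n2)c1` — 4700 nM

All three numbers come from a functional assay on FM3A cells (Mus musculus) for inhibition, read by cell counting, with a stated time of 2 days; on this read-out lower numbers stand for stronger inhibition and higher numbers for weaker inhibition. Compound 1 holds the lowest number of the three. Compound 3 stands nearest to it, and that gap lies beyond the scatter; compound 2 stands furthest, and that gap too lies beyond the scatter. None of the three measured pairs differs in one place only, so no single step between measured compounds can be read off, and no cause for the spread among them is given here.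

Compound 4 `C=C(Br)C(=O)Nc1cccc(-c2cn3nc(-c4cccc(OC)c4)sc3n2)c1` has not yet been measured in this assay. It differs from compound 1 in one place: 3-methoxyphenyl in place of 4-ethoxyphenyl on an aromatic carbon. Going by the values given here, nothing among the measured compounds shows what this kind of exchange does on this core, so the expectation rests on compound 1 alone, with a wide range. A small step toward a somewhat higher number is expected, not clearly beyond the scatter. For compound 4 the expected step from compound 1 is a 1.5-fold higher number from compound 1 to compound 4 (0.16 log units; within the scatter). For compound 4 the estimated value in this assay is 1600 nM, with a range from 500 nM to 5000 nM.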

Compound 4, half-maximal inhibitory concentration: 500 nM
Compound 4: the middle estimate sits 3.2-fold (0.51 log units) above what was measured; measured number inside the range.
By their numbers in this assay, from the lowest: compound 4; then compound 1; then compound 3; then compound 2.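

In this assay, going by these compounds alone, replacing 4-ethoxyphenyl with 3-methoxyphenyl on the aromatic carbon of the shared core brings a 2.2-fold lower number from compound 1 to compound 4 (0.34 log units; beyond the scatter), the first step that can be read at a single place; it is modest, but it lies beyond the scatter. This position therefore responds to an aryl exchange, and the response here is toward stronger inhibition even though the entering group has one heavy atom fewer and the same counts of hydrogen-bond donors and acceptors as the group that leaves. No measurement at hand bears on the reason for this shift, so the step stands as an observation only.

The exchange changes both the place of the ether on the phenyl ring and the length of its chain, so this single step leaves the two changes unseparated, and 4-methoxyphenyl or 3-ethoxyphenyl on the same core would be needed to tell them apart. Also open, as far as these compounds go, is how the number responds at this position to an aryl group bearing an amine or a carboxylic acid in place of the ether.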